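The compounds below may be only part of what the source reports. "The series", "measured", "known", "first", "only" and "open" are said of these compounds alone.

In a functional assay on SGC-7901 cells (Homo sapiens) for inhibition, read by MTT assay, with a stated time of 24 h (on this read-out higher numbers stand for weaker inhibition and lower numbers for stronger inhibition), compound 1 `CC1(C)[C@H]2CC[C@]1(C)N(Cc1cn(-c3ccccc3Cl)nn1)C(=O)C2` gives 220 nM, compound 2 `CC1(C)[C@H]2CC[C@]1(C)N(Cc1cn(-c3ccc(O)cc3)nn1)C(=O)C2` gives 330 nM and compound 3 `Cc1ccccc1-n1cc(CN2C(=O)C[C@@H]3CC[C@@]2(C)C3(C)C)nn1` gives 350 nM. Compound 3 is not separated from either of the others: the steps to it are a 1.6-fold higher number from compound 1 to compound 3 (0.20 log units; within the scatter) and a 1.1-fold higher number from compound 2 to compound 3 (0.03 log units; within the scatter). Compound 4 `CC1(C)[C@H]2CC[C@]1(C)N(Cc1cn(-c3cccc(Br)c3)nn1)C(=O)C2` has 3-bromophenyl in place of 2-methylphenyl on an aromatic nitrogen, (3-bromophenyl in place of 2-methylphenyl on an aromatic nitrogen). The measured steps at this same place bear on it, including a 1.5-fold higher number from compound 1 to compound 2 (0.18 log units; within the scatter), and all of them stay within the scatter. For the measured compounds named here, none of the measured compounds carries bromine, so this rests on three compounds only. In this assay, no step beyond the scatter is expected, and the estimate is a 1.2-fold lower number from compound 3 to compound 4 (0.08 log units; within the scatter). For compound 4 the estimated value is 290 nM, with an expected range from 120 nM to 700 nM.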

Compound 4, half-maximal inhibitory concentration: 120 nM
Compound 4: the middle estimate sits 2.4-fold (0.38 log units) above what was measured, within the range that was stated.
By their numbers in this assay, from the lowest: compounds 4, 1, 2 and 3 (each within the scatter of the next, the first and the last beyond it).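

For the compounds shown here, on the aromatic nitrogen, 3-bromophenyl gives the first steps beyond the scatter in this assay, with a 2.9-fold lower number from compound 3 to compound 4 (0.46 log units; beyond the scatter) and a 2.8-fold lower number from compound 2 to compound 4 (0.44 log units; beyond the scatter), whereas the earlier changes at this place all stayed within it. Compound 4 is still not separated from the 2-chlorophenyl of compound 1, with a 1.8-fold lower number from compound 1 to compound 4 (0.26 log units; within the scatter) as the step. Nothing available here accounts for these steps.

The compounds shown leave open whether the steps follow the bromine itself or the place it occupies on the phenyl ring. A 3-chlorophenyl or a 4-bromophenyl group on the same nitrogen would bear on that question.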